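The source may hold more compounds than are shown below. What is called first, only, known or untested is meant among the compounds shown, and "the series" means these compounds.

Among the compounds with values here, compound 2, `N=C(NCc1ccc(O)cc1)[C@@H]1CCC(=O)N1Cc1ccc([N+](=O)[O-])cc1`, gives 25.9% in a functional assay on SH-SY5Y cells (Homo sapiens) for cytotoxicity, read by MTT assay, with stated times of 8 h, 30 min and 12 h, tested at 0.05 uM (a higher number here means a stronger effect of the compound at the concentration tested, a lower number a weaker effect), and it stands highest of the two numbers measured so far. Its nearest neighbour is compound 1, `N=C(NCc1ccccc1)[C@@H]1CCC(=O)N1Cc1ccc([N+](=O)[O-])cc1`, which in this assay gives 13.7%. Within the data shown here, the only measured step, a number 12.2 percentage points higher from compound 1 to compound 2 (beyond the scatter), is a modest one that lies beyond the scatter.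

The next compound, compound 3, `COc1ccc(CNC(=N)[C@@H]2CCC(=O)N2Cc2ccc([N+](=O)[O-])cc2)cc1`, differs from compound 2 in one place: methyl in place of hydrogen on an oxygen on an aromatic ring. Among the measured compounds shown here, the change is small in size, but no measured pair shows methyl in place of hydrogen on an oxygen on an aromatic ring, so there is no step that bears directly on it. For the measured compounds named here, the only step available concerns the hydroxy group itself, from compound 1 to compound 2, and it tells how much that group is worth when it is present; it does not tell what happens when its hydrogen is replaced by methyl.

Compound 3 is therefore expected to fall between the two measured values, and the estimate for it in this assay is 20%, within a range from 8% to 33%. That estimate means a step of a number 5.9 percentage points lower from compound 2 to compound 3 (within the scatter), which is expected to lie within the scatter or a little beyond it.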

Compound 3, a percentage reported as activity, at one concentration (the size of the read-out at that concentration, not a potency): 14.3%
For compound 3 the middle estimate is 5.7 percentage points above the measured one; the range from low to high includes it.
By their numbers in this assay, from the lowest: compounds 1 and 3 (each within the scatter of the next); then compound 2.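

In this assay, methyl in place of hydrogen on an oxygen on an aromatic ring does not preserve the read-out of the hydroxy compound: the change gives a number 11.6 percentage points lower from compound 2 to compound 3 (beyond the scatter). The comparison with the compound that lacks any such group gives a number 0.6 percentage points higher from compound 1 to compound 3 (within the scatter), so compound 3 cannot be told apart from compound 1, and of these three compounds only compound 2, which carries the free hydroxy group, stands apart from the others. The information at hand offers no explanation for this difference between hydroxy and methoxy.

The compounds shown leave open whether the read-out depends on that hydrogen specifically or would also respond to other groups at this place, such as an amine or a carboxylic acid in place of the hydroxy group, or an ethyl group or a longer chain in place of the methyl on the oxygen. Since every number here comes from a single concentration, they also leave open how compound 2 and compound 3 would compare at other concentrations in this assay.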